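Aryl group exchange from compound 3 to compound 4

This account rests on a few compounds, and the source may have more. Where it says the series, first, only, none or still open, it means among the compounds named here.

Measured in a functional assay on KBVIN cells (Homo sapiens) for antiproliferative activity, read by sulforhodamine B assay, with a stated time of 3 days; a higher number here means that more compound is needed for the effect, a lower number that less compound is needed:
compound 1 `CCC1=C(O)c2c(oc(-c3ccc(C(C)C)cc3)cc2=O)C(CC)(CC)C1=O` gives 1.08 uM
compound 2 `CCCCc1ccc(-c2cc(=O)c3c(o2)C(CC)(CC)C(=O)C(CC)=C3O)cc1` gives 37 uM
compound 3 `CCC1=C(O)c2c(oc(-c3ccc(SC)cc3)cc2=O)C(CC)(CC)C1=O` gives 1.38 uM

Compound 3 stands with compound 1 at the low end of these numbers. The gap there, a 1.3-fold higher number from compound 1 to compound 3 (0.11 log units; within the scatter), lies within the scatter, whereas a 27-fold lower number from compound 2 to compound 3 (1.43 log units; beyond the scatter) is large.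

The next change leads to compound 4 `CCC1=C(O)c2c(oc(-c3cccc(OC)c3)cc2=O)C(CC)(CC)C1=O` and puts 3-methoxyphenyl in place of 4-(methylsulfanyl)phenyl on an aromatic carbon next to the ring oxygen 3-methoxyphenyl in place of 4-(methylsulfanyl)phenyl on an aromatic carbon and the rest of the shared core stays the same.

The measured steps bear on it only indirectly, since each alters a group on this same aryl ring and none involves 3-methoxyphenyl. Methylsulfanyl in place of isopropyl gave a 1.3-fold higher number from compound 1 to compound 3 (0.11 log units; within the scatter) and stayed within the scatter, while butyl in place of isopropyl gave a 34-fold higher number from compound 1 to compound 2 (1.53 log units; beyond the scatter) and is large. Single changes here have therefore run from no visible step to a large one.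

Starting from compound 3 at 1.38 uM and given the reach shown by compound 2 at 37 uM for this series, a modest upward step is expected, with more room upward than downward. The expected size is a 2.2-fold higher number from compound 3 to compound 4 (0.34 log units; beyond the scatter) and this estimate remains uncertain. In this assay the estimate for compound 4 is 3 uM and the expected range runs from 0.9 uM to 15 uM for now.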

Compound 4, concentration for half-maximal effect: 1.22 uM
Beside the measured number, compound 4's estimate is 2.5-fold (0.39 log units) above it; low and high end bracket the measured number.
By their numbers in this assay, from the lowest: compounds 1, 4 and 3 (each within the scatter of the next); then compound 2.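

Going by these compounds alone, exchanging 4-(methylsulfanyl)phenyl for 3-methoxyphenyl gives a 1.1-fold lower number from compound 3 to compound 4 (0.05 log units; within the scatter) in this assay, so this aryl group can change in both substituent and ring location with no visible step, a kind of change that the earlier steps, each swapping one group for another, did not include. The comparison with the 4-isopropylphenyl group reads the same, a 1.1-fold higher number from compound 1 to compound 4 (0.05 log units; within the scatter), and compound 1, compound 3 and compound 4 cannot be ordered among themselves. Among the four compounds shown, compound 2 at 37 uM remains the only one standing apart, so the large shift in this series is still tied to the butyl group alone and is not shared by 3-methoxyphenyl.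

This exchange alters the substituent and its ring location together, so the two contributions stay unseparated; 4-methoxyphenyl and 3-(methylsulfanyl)phenyl would divide them, while a longer chain, an amine or a carboxylic acid on the same ring would test how far this flat stretch extends. Nothing available here explains why the butyl compound alone departs from the others.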